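The source may hold more compounds than are shown below. What is called first, only, known or untested is meant among the compounds shown, and "the series" means these compounds.

Compound 1, `O=C(O)CCc1ccc(NCc2ccc(Cl)cc2)cc1`: 111% in a functional assay on CHO cells for agonist activity at Free fatty acid receptor 1 (Homo sapiens), read by reporter gene assay; a higher number here means a larger maximal response, a lower number a smaller maximal response
Compound 2, `O=C(O)CCc1ccc(NCc2ccc(C(F)(F)F)cc2)cc1`: 133%

Within the data shown here, of the two numbers so far in this assay, compound 2 holds the higher; compound 1 is its only neighbour, and the one measured step, a number 22 percentage points higher from compound 1 to compound 2 (beyond the scatter), is modest and came with trifluoromethyl in place of chloro on an aromatic carbon. Compound 3, `Cc1ccc(CNc2ccc(CCC(=O)O)cc2)cc1`, differs from compound 2 by methyl in place of trifluoromethyl on an aromatic carbon. Among the measured compounds shown here, no measured step covers this exchange; the single step on the same aromatic carbon was modest, so a modest step in this assay, more likely downward than upward, is expected. Compound 3 is expected at 115%, between 95% and 135%. That corresponds to an expected a number 18 percentage points lower from compound 2 to compound 3 (beyond the scatter).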

Compound 3, largest response reached (reported as percent of maximum), in percent of the reference or control that the assay uses: 152%
Compound 3: the middle estimate sits 37 percentage points below what was measured; the whole stated range lies below it.
By their numbers in this assay, from the lowest: compound 1; then compound 2; then compound 3.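

On this aromatic carbon, methyl in place of trifluoromethyl raised the maximal response in this assay (a number 19 percentage points higher from compound 2 to compound 3 (beyond the scatter)), so the rise seen on going from chloro to trifluoromethyl does not carry over to methyl as a further drop. Methyl in place of chloro gave the larger change (a number 41 percentage points higher from compound 1 to compound 3 (beyond the scatter)), which places compound 3 beyond the scatter above both other compounds. No measurement at hand bears on why the three groups fall in this order. Going by these compounds, whether an ethyl or a methoxy group on the same carbon would exceed compound 3 remains open.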